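The source may hold more compounds than are shown below. What is called first, only, known or untested is meant among the compounds shown, and "the series" means these compounds.

Compound 1 `COc1cc(-c2nnc3n2NC(c2ccco2)C(C(=O)c2ccc(Cl)cc2)S3)cc(OC)c1OC` — in a functional assay on A549 cells (Homo sapiens) for cytotoxicity, read by MTT assay, with a stated time of 48 h (on this read-out lower numbers stand for stronger inhibition and higher numbers for weaker inhibition), compound 1 gives 51400 nM
Compound 2 `COc1cc(-c2nnc3n2NC(c2cccs2)C(C(=O)c2ccc(C)cc2)S3)cc(OC)c1OC` — in this assay compound 2 gives 12700 nM

Of these two numbers, compound 2 has the lower one, and its gap to compound 1 lies beyond the usual scatter. Compound 3 `COc1cc(C(=O)C2Sc3nnc(-c4cc(OC)c(OC)c(OC)c4)n3NC2c2cccs2)cc(OC)c1OC` is not yet measured. It differs from compound 2 in one place: 3,4,5-trimethoxyphenyl in place of 4-methylphenyl on a carbonyl carbon. Within the data shown here, no measured pair in this small set shows that same change on its own, so the size of the step in this assay cannot be read from neighbours; the expectation is a step of modest size, perhaps none beyond the scatter. Compound 3 is thus estimated at 16000 nM, within 4000 nM to 60000 nM, and the expected step of a 1.3-fold higher number from compound 2 to compound 3 (0.10 log units; within the scatter) is small.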

Compound 3, half-maximal inhibitory concentration: > 100000 nM
Compound 3: only a limit was reported (the forecaster's own chance of this, stated with the estimate: 10%); middle value at least 6.2-fold (0.79 log units) from the limit.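

In this assay, among these compounds, the first one-place change in this set shows that the group on this carbonyl carbon matters: 3,4,5-trimethoxyphenyl in place of 4-methylphenyl gives an at least 7.8-fold higher number from compound 2 to compound 3 (0.89 log units; beyond the scatter). The entry for compound 3 is a limit, not a number: the limit of > 100000 nM in this assay, at which 1 of the 3 values shown sits.

On these data alone, the full size of the step therefore stays open. It is also unclear whether all three methoxy groups are needed for this weakening, or how a phenyl ring carrying a single methoxy group or an amine would read.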